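From methoxy to methylamino on a shared core

A few compounds are considered here, and "the series" means these few. Any claim that something is new, unique, unknown or untested is made for them only; others in the source may bear on it.

Compound 1 `COc1ncnc2c1c(-c1cc3ccccc3o1)cn2[C@@H]1O[C@H](CO)[C@@H](O)[C@H]1O` gives 5370 nM 
Compound 2 `CSc1ncnc2c1c(-c1ccccc1)cn2[C@@H]1O[C@H](CO)[C@@H](O)[C@H]1O` gives > 20000 nM 

Going by the values given here, both compounds were tested in a functional assay on CCRF-CEM cells (Homo sapiens), read by MTT assay, with a stated time of 72 h (a lower number here means a stronger inhibitor, a higher number a weaker inhibitor), and compound 1 gives 5370 nM there as the only actual number on hand. Compound 2 has > 20000 nM as its result, which is a limit and not a number. Compound 3 `CNc1ncnc2c1c(-c1cc3ccccc3o1)cn2[C@@H]1O[C@H](CO)[C@@H](O)[C@H]1O` keeps the core of compound 1 and has methylamino in place of methoxy on an aromatic carbon with nothing else altered. Among the compounds with values here, no measured pair shows this swap, so in this assay no step beyond the scatter is expected and no direction is favoured. The estimate amounts to a 1.3-fold lower number from compound 1 to compound 3 (0.13 log units; within the scatter) as the expected step. Compound 3 is estimated at 4000 nM with an expected range from 800 nM to 20000 nM for its value.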

Compound 3, half-maximal inhibitory concentration: > 20000 nM
Compound 3 ended at the assay's limit (the forecaster's own chance of this, stated with the estimate: 25%); middle value at least 5.0-fold (0.69 log units) from the limit.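

Going by these compounds alone, replacing methoxy with methylamino gives the first readable step at this aromatic carbon next to the ring nitrogen, with everything else on the shared core unchanged: in this assay the change gives an at least 3.7-fold higher number from compound 1 to compound 3 (0.57 log units; beyond the scatter) and shows that this position does not tolerate every small group equally. From the compounds shown here alone, for compound 3 the result of > 20000 nM is a limit and not a number, so the step sets only a minimum and its full size stays unknown. Compound 1 remains the only compound shown with an actual number: the limit of > 20000 nM in this assay, at which 2 of the 3 values shown sit.

Whether the hydrogen-bond donor that enters with methylamino accounts for the step stays open, as no compound shown separates it from the exchange of oxygen for nitrogen. Dimethylamino or a plain methyl at this carbon would bear on that question, as would methylsulfanyl on the core of compound 1, given that compound 2 differs from compound 1 in more than one place.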